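This account rests on a few compounds, and the source may have more. Where it says the series, first, only, none or still open, it means among the compounds named here.

Measured so far:
compound 1 `Fc1ccc(CN2CCC(NCCSC(c3ccc(F)cc3)c3ccc(F)cc3)CC2)cc1`: 13.3 nM
compound 2 `[O-][S+](CCNC1CCN(CC(O)Cc2ccccc2)CC1)C(c1ccc(F)cc1)c1ccc(F)cc1`: 351 nM
compound 3 `Fc1ccc(C(SCCNC2CCN(Cc3cc4ccccc4o3)CC2)c2ccc(F)cc2)cc1`: 205 nM

In an assay on membranes from Cortex for displacement of a labelled ligand from Sigma non-opioid intracellular receptor 1 (Cavia porcellus), read by scintillation counting, with a stated time of 120 min (on this read-out higher numbers stand for weaker inhibition and lower numbers for stronger inhibition), compound 2 stands at a number far beyond the scatter from compound 1 and within the scatter of compound 3. Compound 4 `O=C(c1ccc(F)cc1)N1CCC(NCC[S+]([O-])C(c2ccc(F)cc2)c2ccc(F)cc2)CC1` differs from compound 2 in one place: (4-fluorophenyl)carbonyl in place of 2-hydroxy-3-phenylpropyl on an amine nitrogen in a ring. Within the data shown here, no measured step makes this kind of change. Among the measured compounds shown here, the only step that touches the same ring nitrogen, a 15-fold higher number from compound 1 to compound 3 (1.19 log units; beyond the scatter), exchanged one aromatic group on a chain carbon for another and was large. That step does not show what a carbonyl-linked ring in place of the whole chain does, so the expectation is uncertain, and a moderate rise in the number is expected, a 2.8-fold higher number from compound 2 to compound 4 (0.45 log units; beyond the scatter). Compound 4 is estimated at 1000 nM, between 200 nM and 5000 nM.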

Compound 4, inhibition constant: 1440 nM
Beside the measured number, compound 4's estimate is 1.4-fold (0.16 log units) below it; the measured number falls inside the stated range.
By their numbers in this assay, from the lowest: compound 1; then compounds 3 and 2 (each within the scatter of the next); then compound 4.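

In this assay, the change on this ring nitrogen gives a 4.1-fold higher number from compound 2 to compound 4 (0.61 log units; beyond the scatter), so inhibition weakens modestly, by a step beyond the scatter. This is the only step shown in which a carbonyl joins the group directly to that nitrogen, and the ring with its fluorine does not restore the stronger inhibition. Nothing measured here gives a reason for the step.

As far as these compounds go, whether the carbonyl, the fluorine or the loss of the hydroxy group drives the change stays open. An unfluorinated benzoyl group or a plain 3-phenylpropyl chain on this nitrogen would help separate them.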